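The source may hold more compounds than are shown below. What is called first, only, known or untested is meant among the compounds shown, and "the series" means these compounds.

Of the compounds shown here, two have numbers so far. Compound 1 `Cc1ccc(S(=O)(=O)Nc2ccc3c(c2)C(=O)N(CCNc2ccc(O)c(O)c2)C3=O)cc1` gives 66600 nM in an assay on isolated protein for inhibition of lactase/phlorizin hydrolase (Rattus norvegicus), read by colorimetric assay; on this read-out higher numbers stand for weaker inhibition and lower numbers for stronger inhibition. Compound 2 `Cc1ccc(S(=O)(=O)Nc2ccc3c(c2)C(=O)N(Cc2ccc(Cl)c(Cl)c2)C3=O)cc1` gives 101000 nM in this assay. Going by the values given here, the one measured step, a 1.5-fold higher number from compound 1 to compound 2 (0.18 log units; within the scatter), lies within the scatter, so compound 2 stands alongside compound 1 with no separation that the numbers support.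

Compound 3 `Cc1ccc(S(=O)(=O)Nc2ccc3c(c2)C(=O)N(CCOc2ccc(O)cc2)C3=O)cc1` is not yet measured. It differs from compound 2 by (4-hydroxyphenoxy)methyl in place of 3,4-dichlorophenyl on a saturated chain carbon bound to an amide-type nitrogen in a ring. Among the compounds with values here, the only step that bears on this change is the exchange at the same place, a 1.5-fold higher number from compound 1 to compound 2 (0.18 log units; within the scatter), which stayed within the scatter even though the groups exchanged were quite unlike one another. No step beyond the scatter in this assay is therefore expected for the move to compound 3, and the estimated step is a 1.3-fold lower number from compound 2 to compound 3 (0.13 log units; within the scatter). Compound 3 is expected to give about 75000 nM in this assay, with a range from 30000 nM to 190000 nM.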

Compound 3, half-maximal inhibitory concentration: 100000 nM
Compound 3: the middle estimate sits 1.3-fold (0.12 log units) below what was measured, within the range that was stated.
By their numbers in this assay, from the lowest: compounds 1, 3 and 2 (each within the scatter of the next).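

In this assay, (4-hydroxyphenoxy)methyl in place of 3,4-dichlorophenyl on a saturated chain carbon bound to an amide-type nitrogen in a ring gives a 1.0-fold lower number from compound 2 to compound 3 (0.00 log units; within the scatter) and 4-hydroxyphenoxy in place of (3,4-dihydroxyphenyl)amino gives a 1.5-fold higher number from compound 1 to compound 3 (0.18 log units; within the scatter). All three groups at this place now lie within the scatter of one another, including the chlorine-bearing ring of compound 2 and the hydroxy-bearing rings of compound 1 and compound 3, so no separation among these groups can be read. Nothing at hand accounts for this flat reading.

Still open, on these data alone, is whether any group at this place separates from these three, for instance a carboxylic acid or a primary amine at the chain end. Also open, as far as these compounds go, is whether a longer chain carrying the same 4-hydroxyphenoxy group would read differently.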